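Chloro on the benzyl phenyl: compound 2 to compound 4

The compounds below may be only part of what the source reports. "The series", "measured", "known", "first", "only" and "open" are said of these compounds alone.

Compound 2 `CC(C)(CO)COC1(c2ccc(Cl)cc2)c2ccccc2C(=O)N1Cc1ccccc1` stands at the high end of the three numbers in a functional assay on HCT-116 cells (Homo sapiens) for inhibition, read by fluorescence, with a stated time of 48 h (a lower number here means a stronger inhibitor of growth, a higher number a weaker inhibitor of growth), giving 71000 nM. Compound 3 `CC(=O)OCCCOC1(c2ccc(Cl)cc2)c2ccccc2C(=O)N1Cc1ccccc1` gives 50000 nM in this assay, and the step of a 1.4-fold lower number from compound 2 to compound 3 (0.15 log units; within the scatter) shows that exchanging the chain carries no weight here. Compound 1 `N[C@H](C(=O)OCCCOC1(c2ccc(Cl)cc2)c2ccccc2C(=O)N1Cc1ccc(Cl)cc1)c1ccccc1` gives 12000 nM in this assay; it carries the 4-chlorobenzyl, but its chain also differs, so its two values against compound 2 are not a single step and only show that a 4-chlorobenzyl compound sits well below compound 2.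

Compound 4 `CC(C)(CO)COC1(c2ccc(Cl)cc2)c2ccccc2C(=O)N1Cc1ccc(Cl)cc1` is compound 2 with chloro in place of hydrogen on an aromatic carbon. Among the compounds with values here, no measured step isolates this change. Because a 1.4-fold lower number from compound 2 to compound 3 (0.15 log units; within the scatter) carries no weight while compound 1 gives 12000 nM and so sits well below compound 2, the chloro that compound 1 shares with compound 4 is tentatively read as the part that matters, and a lower number is expected for compound 4, though with wide uncertainty. The estimated step is a 2.4-fold lower number from compound 2 to compound 4 (0.37 log units; beyond the scatter). Compound 4 is therefore expected at 30000 nM in this assay, within 10000 nM to 90000 nM.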

Compound 4, concentration for 50% growth inhibition: 50000 nM
Compound 4: the middle estimate sits 1.7-fold (0.22 log units) below what was measured, within the range that was stated.
By their numbers in this assay, from the lowest: compound 1; then compounds 3, 4 and 2 (each within the scatter of the next).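

In this assay, the step of a 1.4-fold lower number from compound 2 to compound 4 (0.15 log units; within the scatter) alone isolates chloro in place of hydrogen on an aromatic carbon of the benzyl phenyl, and on this chain the change carries no weight. The 4-chlorobenzyl does not by itself place a compound low: compound 4 gives 50000 nM while compound 1, with the same 4-chlorobenzyl and a different chain, gives 12000 nM and so directs attention to the chain of compound 1. No measurement at hand offers an explanation for this result.

Still open, on these data alone, is which part of the chain of compound 1 goes with its lower number, the amine or the phenyl, and a chain ending in a plain amine or a carboxylic acid would help separate them. Also open, as far as these compounds go, is how methoxy or fluoro would read at the place held by chloro.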